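Swapping Nitro for Bromo on the Aryl Group

This account rests on a few compounds, and the source may have more. Where it says the series, first, only, none or still open, it means among the compounds named here.

Compounds 1, 2 and 3 share one core and differ only in the aryl group carried on an aromatic nitrogen. Compound 1 `Cc1ccc(-n2c(-c3coc4cc(C)c(Cl)cc4c3=O)nc(-c3ccccc3)c2-c2ccccc2)c(C)c1` gives 6250 nM in a functional assay on A549 cells (Homo sapiens) for inhibition, read by MTT assay, with a stated time of 72 h; on this read-out higher numbers stand for weaker inhibition and lower numbers for stronger inhibition. Compound 2 `COc1cccc(-n2c(-c3coc4cc(C)c(Cl)cc4c3=O)nc(-c3ccccc3)c2-c2ccccc2)c1` gives 6250 nM in this assay. Compound 3 `Cc1cc2occ(-c3nc(-c4ccccc4)c(-c4ccccc4)n3-c3ccc([N+](=O)[O-])cc3)c(=O)c2cc1Cl` gives 3130 nM in this assay. Compound 3 holds the lowest number of the three, yet a 2.0-fold lower number from compound 1 to compound 3 (0.30 log units; within the scatter) and a 2.0-fold lower number from compound 2 to compound 3 (0.30 log units; within the scatter) both lie within the scatter, as does no change at the digits printed from compound 1 to compound 2 (within the scatter), so no order among the three can be claimed.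

Compound 4 `Cc1cc2occ(-c3nc(-c4ccccc4)c(-c4ccccc4)n3-c3ccc(Br)cc3)c(=O)c2cc1Cl` differs from compound 3 by bromo in place of nitro on an aromatic carbon. Among the compounds with values here, no measured step involves bromo, so the nearest guide is what the three measured changes to the group on the aromatic nitrogen did: every one of them gave a step within the scatter. Another swap at the same place is therefore expected to give a step of about a 1.3-fold higher number from compound 3 to compound 4 (0.11 log units; within the scatter), that is, nothing beyond the scatter. Compound 4 is estimated at 4000 nM in this assay, with a likely range from 1500 nM to 12000 nM.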

Compound 4, half-maximal inhibitory concentration: 25000 nM
Estimate against measurement, compound 4: 6.3-fold (0.80 log units) below, outside the stated range (above it).
By their numbers in this assay, from the lowest: compounds 3, 1 and 2 (each within the scatter of the next); then compound 4.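

Within the data shown here, the group on the aromatic nitrogen turns out to be less forgiving than the first three compounds suggested: in this assay, the change from nitro to bromo gives an 8.0-fold higher number from compound 3 to compound 4 (0.90 log units; beyond the scatter), the first step here to leave the scatter. The other two aryl groups give the same picture, with a 4.0-fold higher number from compound 2 to compound 4 (0.60 log units; beyond the scatter) and a 4.0-fold higher number from compound 1 to compound 4 (0.60 log units; beyond the scatter), so compound 4 is the weakest of the four, though these steps are modest in size. Nothing shown here explains why this swap has a larger effect than the earlier ones.

Whether the loss belongs to bromo alone stays open, as compound 4 is the only bromo compound shown. A chloro, an amine or a carboxylic acid on the same aromatic carbon would show whether other groups there behave like bromo or like nitro.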